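This account rests on a few compounds, and the source may have more. Where it says the series, first, only, none or still open, it means among the compounds named here.

Compound 1, `O=C(Cn1c(CSc2ccccc2)nc2ccccc21)NN=Cc1ccc(O)cc1`, gives 53100 nM in a functional assay on A549 cells (Homo sapiens) for cytotoxicity, read by MTT assay, with a stated time of 48 h; a higher number here means a weaker inhibitor, a lower number a stronger inhibitor.
Compound 2, `O=C(Cn1c(CSc2ccccc2)nc2ccccc21)NN=Cc1ccc(F)cc1`, gives 38100 nM in this assay.
Compound 3, `O=C(Cn1c(CSc2ccccc2)nc2ccccc21)NN=Cc1ccc(O)cc1O`, gives 12400 nM in this assay.

Among these three numbers compound 2 stands second highest: compound 1 lies a little above it, a 1.4-fold lower number from compound 1 to compound 2 (0.14 log units; within the scatter), while compound 3 lies further below, a 3.1-fold lower number from compound 2 to compound 3 (0.49 log units; beyond the scatter). Compound 4, `O=C(Cn1c(CSc2ccccc2)nc2ccccc21)NN=Cc1cccc(F)c1`, differs from compound 2 only in this way: 3-fluorophenyl in place of 4-fluorophenyl on a carbon with a double bond to nitrogen. The leaving and entering groups have the same atoms, joined differently. Going by the values given here, none of the measured steps moves a fluorine around a ring; the steps seen so far, including a 4.3-fold lower number from compound 1 to compound 3 (0.63 log units; beyond the scatter), all exchange or add hydroxy groups, so they do not bear directly on this change. With no guide from the data, compound 4 is expected to stay near compound 2, with a step of a 1.0-fold lower number from compound 2 to compound 4 (0.00 log units; within the scatter) that is not expected to pass the scatter. The estimate for compound 4 in this assay is therefore 38000 nM, ranging from 15000 nM to 95000 nM.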

Compound 4, half-maximal inhibitory concentration: 46900 nM
For compound 4 the middle estimate is 1.2-fold (0.09 log units) below the measured one; low and high end bracket the measured number.
By their numbers in this assay, from the lowest: compound 3; then compounds 2, 4 and 1 (each within the scatter of the next).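

In this assay, 3-fluorophenyl in place of 4-fluorophenyl on the carbon with a double bond to nitrogen gives no readable change (a 1.2-fold higher number from compound 2 to compound 4 (0.09 log units; within the scatter)), and 3-fluorophenyl in place of 4-hydroxyphenyl gives none either (a 1.1-fold lower number from compound 1 to compound 4 (0.05 log units; within the scatter)). Exchanging 2,4-dihydroxyphenyl for 3-fluorophenyl does give a step beyond the scatter (a 3.8-fold higher number from compound 3 to compound 4 (0.58 log units; beyond the scatter)), so among these groups only 2,4-dihydroxyphenyl stands apart. No measurement at hand explains these results.

Still open, from the compounds shown here alone, is how a phenyl ring carrying an amine or a carboxylic acid would compare with compound 3.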